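This account rests on a few compounds, and the source may have more. Where it says the series, first, only, none or still open, it means among the compounds named here.

Measured so far in a physicochemical assay for lipophilicity, using the shake flask method, measured as octanol-water partition, at pH 7.4; a higher number here means a more lipophilic compound, a lower number a more polar compound:

compound 1, `CN(C)CCCOc1ccc(C(=O)/C=C/c2ccccc2)cc1`, gives 1.59
compound 2, `CCCN(CCC)CCCOc1ccc(C(=O)/C=C/c2ccccc2)cc1`, gives 1.91
compound 3, `CN(C)CCCCOc1ccc(C(=O)/C=C/c2ccccc2)cc1`, gives 1.64

Compound 1 holds the lowest of the three numbers in this assay. Its nearest neighbour is compound 3, which sits within the scatter of it; the furthest is compound 2, whose step is beyond the scatter.

The step to be followed goes from compound 1 to compound 4, `CCCN(CCC)CCCCOc1ccc(C(=O)/C=C/c2ccccc2)cc1`, not yet measured. The change is (dipropylamino)methyl in place of dimethylamino on a saturated chain carbon, three bonds along the chain from an oxygen on an aromatic ring. It combines the two changes already measured from compound 1: the amine substituents grow from dimethyl to dipropyl, as in compound 2, and the chain gains one carbon, as in compound 3.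

Both measured steps bear on it. The amine change alone gave a number 0.32 log units higher from compound 1 to compound 2 (beyond the scatter). The chain extension alone gave a number 0.05 log units higher from compound 1 to compound 3 (within the scatter). Between compounds 2 and 3 the difference is a number 0.27 log units lower from compound 2 to compound 3 (within the scatter). Adding the two single changes, the step to compound 4 is expected to be modest and upward, driven mainly by the dipropyl part: a number 0.37 log units higher from compound 1 to compound 4 (beyond the scatter).

For compound 4 in this assay the estimate is 1.96, expected to lie between 1.66 and 2.26.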

Compound 4, partition coefficient: 1.95
Compound 4: the middle estimate sits 0.01 log units above what was measured, and the stated range covers the measured number.
By their numbers in this assay, from the lowest: compounds 1, 3, 2 and 4 (each within the scatter of the next, the first and the last beyond it).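

In this assay, dipropylamino in place of dimethylamino can now be read on the longer chain as well: it gives a number 0.31 log units higher from compound 3 to compound 4 (beyond the scatter), much the same size as a number 0.32 log units higher from compound 1 to compound 2 (beyond the scatter), so this step did not depend on which of the two chains carries the amine. Read the other way, (dipropylamino)methyl in place of dipropylamino gives a number 0.04 log units higher from compound 2 to compound 4 (within the scatter), which matches the dimethylamino pair with a number 0.05 log units higher from compound 1 to compound 3 (within the scatter); in these four compounds the amine change and the chain change therefore behave as independent steps, none of the four goes against this, and together they give a number 0.36 log units higher from compound 1 to compound 4 (beyond the scatter). Nothing at hand offers an explanation for why the two changes combine in this way.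

From the compounds shown here alone, it remains open whether the same independence holds for a cyclic amine such as piperidine or morpholine in place of the dipropylamino group. Among the compounds shown here, it is also open whether a longer chain than the one in compound 4 would still give a step within the scatter, or whether the pattern would break down there.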